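Swapping Methyl for Chloro on the Shared Core

A few compounds are considered here, and "the series" means these few. Any claim that something is new, unique, unknown or untested is made for them only; others in the source may bear on it.

Within the data shown here, compound 1 (`COC1Oc2ccc(C)cc2C(=O)/C1=C\Nc1cccc(S(N)(=O)=O)c1`) holds the lowest of the two numbers measured so far in an assay on isolated protein for inhibition of Intestinal-type alkaline phosphatase (Bos taurus), read by luminescence, with stated times of 5 min and 15 min; a lower number here means a stronger inhibitor, a higher number a weaker inhibitor: compound 1 gives 6560 nM. Compound 2 (`CCCCOC1Oc2ccccc2C(=O)/C1=C\Nc1ccc(S(N)(=O)=O)cc1`) is a much weaker inhibitor, and the gap between the two lies outside the usual scatter; compound 2 gives 48300 nM. Compound 3 (`COC1Oc2ccc(Cl)cc2C(=O)/C1=C\Nc1cccc(S(N)(=O)=O)c1`) differs from compound 1 only by chloro in place of methyl on an aromatic carbon. Among the measured compounds shown here, no measured pair shows this exact swap, so there is nothing to lean on. The expected step is a 1.3-fold lower number from compound 1 to compound 3 (0.12 log units; within the scatter), a change too small to stand out from the scatter. Compound 3 is therefore estimated at 5000 nM, with a likely range from 1500 nM to 16000 nM.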

Compound 3, half-maximal inhibitory concentration: 31900 nM
Compound 3: the middle estimate sits 6.4-fold (0.80 log units) below what was measured; measured number outside the range, above it.
By their numbers in this assay, from the lowest: compound 1; then compounds 3 and 2 (each within the scatter of the next).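

Chloro in place of methyl on this aromatic carbon gives a 4.9-fold higher number from compound 1 to compound 3 (0.69 log units; beyond the scatter) in this assay, so this position does respond to the group it carries. Even a swap of one heavy atom for another, with no change in hydrogen-bond donors, acceptors or net charge, weakens inhibition here. Nothing available explains this loss.

Still open, going by these compounds, is how this position would respond to a methoxy group, an amine or a longer chain. It is also unknown whether methyl itself is better than a bare hydrogen here.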